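Chloro in place of methylsulfonyl: an expected limit

The compounds below may be only part of what the source reports. "The series", "measured", "known", "first", "only" and "open" are said of these compounds alone.

Compound 1 `C/C(=C\c1cc(-c2ccccc2)cs1)C(N)=O` gives in a functional assay on T-24 cells (Homo sapiens) for cytotoxicity, read by CCK-8 assay, with a stated time of 24 h; on this read-out higher numbers stand for weaker inhibition and lower numbers for stronger inhibition > 50000 nM, a limit of the assay and not a number.
Compound 2 `C/C(=C\c1cc(-c2ccc(S(C)(=O)=O)cc2)cs1)C(N)=O` gives in this assay > 50000 nM, also a limit.

Compound 2 thus stands only at the limit, where both shown values sit (the limit of > 50000 nM in this assay, at which 2 of the 2 values shown sit). The step that the two limits leave unreadable from compound 1 to compound 2 cannot be read from the two limits. Compound 3 `C/C(=C\c1cc(-c2ccc(Cl)cc2)cs1)C(N)=O` differs from compound 2 by chloro in place of methylsulfonyl on an aromatic carbon. Within the data shown here, no measured step reads on this change, and no step beyond the scatter is expected in this assay. For compound 3 the expected value is 60000 nM, between 20000 nM and 200000 nM, most likely reported again as a limit. The expected step is a step that the limit leaves unreadable from compound 2 to compound 3.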

Compound 3, half-maximal inhibitory concentration: > 50000 nM
Compound 3 gave a limit, no number (the forecaster's own chance of this, stated with the estimate: 80%); the middle value lies beyond the limit too.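

Compound 1, compound 2 and compound 3 all give only a limit and no number, so no step among them can be read: the limit of > 50000 nM in this assay, at which 3 of the 3 values shown sit.

The compounds shown leave open whether hydrogen, methylsulfonyl and chloro at this place differ at all in this assay.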